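The source may hold more compounds than are shown below. What is called first, only, known or untested is meant among the compounds shown, and "the series" means these compounds.

Compound 1 `Cc1cc2c(c(Oc3cccc(NS(=O)(=O)c4ccc(Cl)cc4)c3)n1)C(=O)N(C(C)C)C2=O` and compound 2 `Cc1cc2c(c(Sc3cccc(NS(=O)(=O)c4ccc(Cl)cc4)c3)n1)C(=O)N(C(C)C)C2=O` share most of their structure; how their two cores differ is not broken down here. In a functional assay on HEK293 cells for agonist activity at Glucose-dependent insulinotropic receptor (Homo sapiens), read by cAMP accumulation, with a stated time of 30 min (on this read-out higher numbers stand for an effect only at larger amounts of compound and lower numbers for an effect already at smaller amounts), compound 1 gives 13 nM, and compound 2 gives 19 nM; these two values lie within the scatter of each other. Compound 3 `Cc1cc2c(c(Sc3ccc(C)c(NS(=O)(=O)c4ccc(Cl)cc4)c3)n1)C(=O)N(C(C)C)C2=O` carries the change methyl in place of hydrogen on an aromatic carbon relative to compound 2. In this assay compound 3 gives 224 nM, a step of a 12-fold higher number from compound 2 to compound 3 (1.07 log units; beyond the scatter). Compound 4 `Cc1cc2c(c(Oc3ccc(C)c(NS(=O)(=O)c4ccc(Cl)cc4)c3)n1)C(=O)N(C(C)C)C2=O` has not yet been measured; it differs from compound 1 by methyl in place of hydrogen on an aromatic carbon, which is the same change, since the surroundings of the place are described in the same words. Among the compounds with values here, because the one measured instance of this change gave a 12-fold higher number from compound 2 to compound 3 (1.07 log units; beyond the scatter), a step of similar size is expected, a 12-fold higher number from compound 1 to compound 4 (1.06 log units; beyond the scatter) in this assay. Compound 4 is therefore estimated at 150 nM, with a range expected from 50 nM to 450 nM.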

Compound 4, half-maximal effective concentration: 9 nM
Estimate against measurement, compound 4: 17-fold (1.22 log units) above; the whole stated range lies above it.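

In this assay, methyl in place of hydrogen on the aromatic carbon ortho to the ((4-chlorophenyl)sulfonyl)amino group gives a 1.4-fold lower number from compound 1 to compound 4 (0.16 log units; within the scatter), so the large step seen on the core of compound 2 did not carry over to the core of compound 1. The two steps differ clearly: the same change on two cores in this assay, a 12-fold higher number (1.07 log units; beyond the scatter) from compound 2 to compound 3 and a 1.4-fold lower number (0.16 log units; within the scatter) from compound 1 to compound 4, 17-fold (1.23 log units) apart, beyond the scatter of two such steps. This shows that in this series a step measured on one core cannot simply be transferred to the other, but it does not show why the two cores part ways, and two pairs give no rule for any further core.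

As far as these compounds go, it remains open whether ethyl, methoxy or an amine at the same place would also differ between the two cores.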